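Chloro scan on the sulfonamide ring of the oxadiazole series

The compounds below may be only part of what the source reports. "The series", "measured", "known", "first", "only" and "open" are said of these compounds alone.

Measured compounds:
Compound 1, `O=C(Nc1ccc(-c2noc(-c3cccc(NS(=O)(=O)c4ccccc4)c3)n2)c(Cl)c1)c1cccnc1`, in a functional assay on MDA-MB-231 cells (Homo sapiens) for antiproliferative activity, read by MTT assay, with a stated time of 72 h (a lower number here means a stronger inhibitor, a higher number a weaker inhibitor), gives > 10000 nM, which is a limit of the assay.
Compound 2, `O=C(Nc1ccc(-c2noc(-c3cccc(NS(=O)(=O)c4cccc(Cl)c4)c3)n2)c(Cl)c1)c1cccnc1`, in this assay gives > 10000 nM, again a limit of the assay.
Compound 3, `CS(=O)(=O)Nc1ccc(NC(=O)Nc2cccc(-c3nc(-c4ccc(NC(=O)c5cccnc5)cc4Cl)no3)c2)cc1`, in this assay gives 600 nM.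

Compound 1 and compound 2 differ by chloro in place of hydrogen on an aromatic carbon; the step that the two limits leave unreadable from compound 1 to compound 2 cannot be sized, because the limit of > 10000 nM in this assay, at which 2 of the 3 values shown sit, hides both ends of it. Compound 3 belongs to a different core; the difference between the two cores is not broken down here. For the measured compounds named here, compound 3 carries the only numerical value in the set.

Compound 4, `CS(=O)(=O)Nc1ccc(NC(=O)Nc2cccc(-c3nc(-c4ccc(NC(=O)c5cccnc5)cc4Cl)no3)c2)cc1Cl`, is not yet measured. It differs from compound 3 by chloro in place of hydrogen on an aromatic carbon. This is the same kind of change as that from compound 1 to compound 2, but not the same: here the new chloro sits ortho to a methanesulfonamido group as well as meta to a large group, whereas in compound 2 it is only meta to a large group.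

No readable step for this change exists, so the expectation rests on compound 3 alone, at 600 nM, and the step of a 1.2-fold lower number from compound 3 to compound 4 (0.08 log units; within the scatter) is estimated to stay within the usual scatter. Compound 4 is therefore expected to give 500 nM in this assay, likely between 150 nM and 2000 nM.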

Compound 4, half-maximal inhibitory concentration: 600 nM
For compound 4 the middle estimate is 1.2-fold (0.08 log units) below the measured one; the measured number falls inside the stated range.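

In this assay, chloro in place of hydrogen on an aromatic carbon, ortho to a methanesulfonamido group, shows no change at the digits printed from compound 3 to compound 4 (within the scatter). On the core of compound 3, this single pair therefore shows that the added chloro at this place leaves the reading within the scatter, but it does not establish a rule for other places or other cores. The same kind of change on the core of compound 1 cannot be read, so the two cores offer no comparison of step size, because both compound 1 and compound 2 sit at a limit of the assay: the limit of > 10000 nM in this assay, at which 2 of the 4 values shown sit.

The compounds shown leave open whether a different group at this place on the core of compound 3, such as fluoro, methoxy or an amine, would give a step beyond the scatter in this assay. Also open, from the compounds shown here alone, is what happens when the methanesulfonamido group itself gives way to a carboxylic acid or a longer chain.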